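This account rests on a few compounds, and the source may have more. Where it says the series, first, only, none or still open, it means among the compounds named here.

Compound 1 `CN1CCN(c2ccc(C3=NN(S(C)(=O)=O)C(c4ccc(N(C)C)cc4)C3)cc2)CC1` carries a methylsulfonyl on its ring sulfonamide nitrogen and a 4-methylpiperazin-1-yl on an aromatic carbon. In a functional assay on MDA-MB-231 cells (Homo sapiens) for inhibition, read by sulforhodamine B assay, tested at 10 uM (a higher number here means more inhibition at the concentration tested (going by the name of the read-out), a lower number less inhibition), compound 1 gives 0.6%. Compound 2 `Cc1ccc(S(=O)(=O)N2N=C(c3ccc(N4CCN(C)CC4)cc3)CC2c2ccc(N(C)C)cc2)cc1` differs from it by 4-methylphenyl in place of methyl on a sulfonyl sulfur, and in this assay compound 2 gives 10.7%, a step of a number 10.1 percentage points higher from compound 1 to compound 2 (beyond the scatter). Compound 3 `CN(C)c1ccc(C2CC(c3ccc(-n4ccnc4)cc3)=NN2S(C)(=O)=O)cc1` keeps the methylsulfonyl of compound 1 but its core differs by 1H-imidazol-1-yl in place of 4-methylpiperazin-1-yl on an aromatic carbon; in this assay compound 3 gives 12%, which is a number 11.4 percentage points higher from compound 1 to compound 3 (beyond the scatter). Compound 3 holds the highest of the three numbers, but its value and that of compound 2 lie within the scatter of each other, so no order between those two is claimed.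

Compound 4 `Cc1ccc(S(=O)(=O)N2N=C(c3ccc(-n4ccnc4)cc3)CC2c2ccc(N(C)C)cc2)cc1` has not been measured. For the measured compounds named here, it differs from compound 3 by 4-methylphenyl in place of methyl on a sulfonyl sulfur, which is the same change as the one from compound 1 to compound 2, at a place described in the same words: a sulfonyl sulfur whose other neighbour is a sulfonamide nitrogen in a ring. Only that one earlier instance exists among these compounds, and it is modest in size. Compound 4 is therefore expected to show a step of about the same size, a number 9 percentage points higher from compound 3 to compound 4 (within the scatter), because the earlier instance gave a number 10.1 percentage points higher from compound 1 to compound 2 (beyond the scatter). On that basis compound 4 is estimated to give 21% in this assay, with a plausible range from 6% to 36%.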

Compound 4, a percentage reported as inhibition, at one concentration (the size of the read-out at that concentration, not a potency): 50.8%
The estimate for compound 4 lay 29.8 percentage points below the measured number; the measured number lies above the stated range.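

Measured, the exchange of methylsulfonyl for (4-methylphenyl)sulfonyl raises the number on both cores, but in this assay it gives a number 38.8 percentage points higher from compound 3 to compound 4 (beyond the scatter), so the direction of the earlier step carried over while its size did not, and the size depends on the core that receives the change: the same change on two cores in this assay, a number 10.1 percentage points higher (beyond the scatter) from compound 1 to compound 2 and a number 38.8 percentage points higher (beyond the scatter) from compound 3 to compound 4, 28.7 percentage points apart, beyond the scatter of two such steps.
The same four compounds read the other way give a number 40.1 percentage points higher from compound 2 to compound 4 (beyond the scatter) for 1H-imidazol-1-yl in place of 4-methylpiperazin-1-yl, and this step too differs in size from its earlier instance: the same change on two cores in this assay, a number 11.4 percentage points higher (beyond the scatter) from compound 1 to compound 3 and a number 40.1 percentage points higher (beyond the scatter) from compound 2 to compound 4, 28.7 percentage points apart, beyond the scatter of two such steps.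
The two changes therefore do not add up independently in this set, but that is shown by one group of four compounds only, which gives no reason for the difference and no rule for other cores.

The compounds shown leave open whether a plain phenyl or an ethyl on the sulfonyl sulfur would behave like 4-methylphenyl or like methyl, and whether a morpholine or a 1H-pyrazol-1-yl on the aromatic carbon would give a step like that of 1H-imidazol-1-yl. They also leave open how these numbers, each read at a single concentration, relate to the strength of the effect at any other concentration.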